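Swapping a Hydroxy for Hydrogen on a Tolerated Compound

The compounds below may be only part of what the source reports. "The series", "measured", "known", "first", "only" and "open" are said of these compounds alone.

Measured in an ADME assay on RAW264.7 cells (Mus musculus) for cytotoxicity, read by MTT assay, with a stated time of 24 h; a higher number here means that more compound is tolerated, a lower number that less compound is tolerated:
- Compound 1 `C/C=C/CCC(=O)O[C@H]1C=CC2=CC(=O)[C@H](/C(C=O)=C\OC)C[C@]2(C)[C@H]1C`: > 50000 nM
- Compound 2 `C=C(CO)[C@@H]1C[C@@]2(C)C(=CC(=O)C[C@@H]2C)C[C@H]1O`: > 50000 nM

For compound 2, > 50000 nM is a limit and not a number. Compound 3 `C=C(C)[C@@H]1C[C@@]2(C)C(=CC(=O)C[C@@H]2C)C[C@H]1O` differs from compound 2 in one place: hydrogen in place of hydroxy on a saturated chain carbon bound to a double-bonded chain carbon. Among the measured compounds shown here, no measured pair shows what this change does in this assay. With compound 2 resting on (the limit of > 50000 nM in this assay, at which 2 of the 2 values shown sit), no step beyond the scatter is expected, in either direction. The expected step is a number no higher from compound 2 to compound 3 (the limit leaves the size open). Compound 3 is estimated at 50000 nM, with an expected range of 20000 nM to 100000 nM.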

Compound 3, half-maximal cytotoxic concentration: > 50000 nM
Compound 3 ended at the assay's limit; the forecaster's own chance of this, stated with the estimate: 75%; the middle value sits exactly at the limit.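

Compound 2 and compound 3 both rest on a limit and not a number, so no step between them can be read: the limit of > 50000 nM in this assay, at which 3 of the 3 values shown sit.

Left open is whether hydroxymethyl or methyl is better tolerated, and at what concentration any of these compounds harms the cells.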